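Swapping trifluoromethyl for fluoro on a thiophene series

The source may hold more compounds than are shown below. What is called first, only, known or untested is meant among the compounds shown, and "the series" means these compounds.

Compound 1, with the structure `Nc1scc(CN2CCN(c3cccc(C(F)(F)F)c3)CC2)c1C(=O)c1ccc(Cl)cc1`, is the starting point. In a functional assay on CHO cells with adenosine receptor A1 (Homo sapiens) as the target, read by cAMP accumulation and immunoassay, with a stated time of 6 min, tested at 0.1 uM (a higher number here means a weaker effect of the compound at the concentration tested, a lower number a stronger effect), compound 1 gives -30%, a negative reading that marks the strongest effect among the three compounds measured. Compound 2, `Nc1scc(CN2CCC(c3ccc(Cl)cc3)CC2)c1C(=O)c1ccc(Cl)cc1`, gives -2.3% in this assay. Compound 3, `Nc1scc(CN2CCN(c3c(F)cccc3F)CC2)c1C(=O)c1cccc(C(F)(F)F)c1`, gives 1.3% in the same test. Both of these numbers lie well above that of compound 1, further apart than the usual scatter, so compound 1 stands clearly lowest.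

The next compound, compound 4, has the structure `Nc1scc(CN2CCN(c3cccc(F)c3)CC2)c1C(=O)c1ccc(Cl)cc1`. It differs from compound 1 in a single place: fluoro in place of trifluoromethyl on an aromatic carbon. Among the measured compounds shown here, no measured pair shows this exact exchange, so the size of the step is unknown. Since compound 2 and compound 3 both sit near zero while only compound 1 shows a strong effect, the expectation is that losing the trifluoromethyl weakens the effect somewhat, moving the number upward by a number 18 percentage points higher from compound 1 to compound 4 (beyond the scatter). Compound 4 is therefore estimated at -12%, with a plausible range from -35% to 10%.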

Compound 4, a percentage reported as activity, at one concentration (the size of the read-out at that concentration, not a potency): -37%
Compound 4: middle estimate off by 25 percentage points, on the high side; measured number outside the range, below it.
By their numbers in this assay, from the lowest: compounds 4 and 1 (each within the scatter of the next); then compounds 2 and 3 (each within the scatter of the next).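

Replacing trifluoromethyl with fluoro gives a number 7 percentage points lower from compound 1 to compound 4 (within the scatter) in this assay, so the two compounds cannot be told apart in this test. At this place on the six-membered aromatic ring, then, the strong effect of compound 1 does not depend on keeping trifluoromethyl: a group of 4 heavy atoms can give way to 1 heavy atom with no measurable loss. The data offer no reason why the two groups read alike.

The compounds shown leave open whether any group is needed here, since neither a plain hydrogen nor an amine or nitrile appears at this place. On these data alone, whether the same exchange would read alike elsewhere also stays open, as compound 2 and compound 3 differ from compound 1 in more than one place.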